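A few compounds are considered here, and "the series" means these few. Any claim that something is new, unique, unknown or untested is made for them only; others in the source may bear on it.

In an ADME assay on S9 fraction from liver (Rattus norvegicus) for metabolic stability, with a stated time of 1 h (a higher number here means that more of the compound is left, a lower number that less of the compound is left), three compounds have been measured so far. Compound 1 (`N#Cc1cnc(NCc2cnccc2C(F)(F)F)cc1N[C@H]1C[C@@H](O)C1`) gives 70% of its starting amount, compound 2 (`N#Cc1cnc(NCc2cnccc2C(F)(F)F)cc1N[C@H]1C[C@H](O)C1`) gives 82% under the same conditions, and compound 3 (`N#Cc1cnc(NCc2cnccc2C(F)(F)F)cc1NC[C@H]1C[C@@H](O)C1`) gives 44% and so holds the lowest number of the three. Compound 4 (`N#Cc1cnc(NCc2cnccc2C(F)(F)F)cc1NC[C@H]1C[C@H](O)C1`) keeps the atoms and bonds of compound 3: the two compounds have the same atoms and bonds and differ only in configuration as drawn: 2 of 2 stereo elements differ (all stereocentres are inverted: mirror images); a stereocentre at a saturated ring carbon is drawn s in compound 3 and r in compound 4; a stereocentre at a saturated ring carbon is drawn s in compound 3 and r in compound 4 is the whole structural change, so only the configuration as drawn differs.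

Among the measured compounds shown here, the closest precedent comes from the pair carrying 3-hydroxycyclobutyl in place of (3-hydroxycyclobutyl)methyl. For the measured compounds named here, there, the same kind of inversion gave a number 12 percentage points higher from compound 1 to compound 2 (beyond the scatter) and the only thing separating that pair is the fact that compounds 1 and 2 differ only in the configuration as drawn (a single pair, and so thin support). The steps of a number 26 percentage points lower from compound 1 to compound 3 (beyond the scatter) and a number 38 percentage points lower from compound 2 to compound 3 (beyond the scatter) are larger, but they concern the change of group rather than the configuration, and they only show how low compound 3 starts. The step expected in this assay is therefore modest and upward, estimated as a number 11 percentage points higher from compound 3 to compound 4 (beyond the scatter) on the strength of that one precedent. Compound 4 is estimated at 55% (expected range 40% to 70%).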

Compound 4, percent of the compound remaining: 61%
For compound 4 the middle estimate is 6 percentage points below the measured one, within the range that was stated.
By their numbers in this assay, from the lowest: compound 3; then compounds 4 and 1 (each within the scatter of the next); then compound 2.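

In this assay, the inversion now has a second case, as a number 17 percentage points higher from compound 3 to compound 4 (beyond the scatter) stands with a number 12 percentage points higher from compound 1 to compound 2 (beyond the scatter), so the upward direction holds for both the 3-hydroxycyclobutyl and the (3-hydroxycyclobutyl)methyl compounds, and no compound shown goes against it, though two pairs are still a small base: the fact that compounds 3 and 4 differ only in the configuration as drawn

The group change can now also be read among the compounds with the stereocentres drawn r, where a number 21 percentage points lower from compound 2 to compound 4 (beyond the scatter) goes the same way as a number 26 percentage points lower from compound 1 to compound 3 (beyond the scatter) among those drawn s. The remaining step, a number 9 percentage points lower from compound 1 to compound 4 (within the scatter), spans both changes at once, since those two compounds differ in configuration as well as in the group, so it says nothing about either change alone.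

The compounds shown leave open whether the inversion would move the number in the same direction with an amine or a methoxy group in place of the hydroxyl on the cyclobutyl ring, or with a longer chain in place of the methyl link. They also do not tell why the configuration matters here, or what happens to the part of each compound that is no longer left.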